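The compounds below may be only part of what the source reports. "The series", "measured", "known", "first", "only" and "open" are said of these compounds alone.

Working notes on the series. The shared core of compound 1 `O=C(Nc1cc(-c2ccccc2)nn1-c1ccccc1)c1cccc([N+](=O)[O-])c1` carries a 3-nitrophenyl on the carbonyl carbon, and in a functional assay on cells for positive allosteric modulation of metabotropic glutamate receptor 5 (Rattus norvegicus), read by calcium flux (a higher number here means that more compound is needed for the effect, a lower number that less compound is needed), compound 1 gives 39 nM. Going by the values given here, this is the lowest of the three numbers measured so far, but both neighbours lie within the scatter of it: compound 2 `O=C(Nc1cc(-c2ccccc2)nn1-c1ccccc1)c1cc([N+](=O)[O-])cc([N+](=O)[O-])c1` gives 65 nM in this assay, and compound 3 `O=C(Nc1cc(-c2ccccc2)nn1-c1ccccc1Br)c1cccc([N+](=O)[O-])c1` gives 68 nM. The two measured steps are a 1.7-fold higher number from compound 1 to compound 2 (0.22 log units; within the scatter) and a 1.7-fold higher number from compound 1 to compound 3 (0.24 log units; within the scatter); neither moves the number beyond the scatter.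

Compound 4 `Cc1ccc(C(=O)Nc2cc(-c3ccccc3)nn2-c2ccccc2)cn1` differs from compound 1 in one place: 6-methylpyridin-3-yl in place of 3-nitrophenyl on a carbonyl carbon. Among the compounds with values here, no measured step exchanges the whole ring on the carbonyl carbon. The step from compound 1 to compound 2 touches the same ring, adding a second nitro without a change beyond the scatter, so that ring appears to tolerate substitution; the step to compound 3 concerns a different ring and gives no information on this exchange. Within the data shown here, the removal of the nitro together with the change of ring type has no precedent here, so the expectation is a modest upward step, a 2.8-fold higher number from compound 1 to compound 4 (0.45 log units; beyond the scatter), with a wide range. For compound 4 in this assay the estimate is 110 nM, expected to fall between 30 nM and 450 nM.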

Compound 4, half-maximal effective concentration: 280 nM
Estimate against measurement, compound 4: 2.5-fold (0.41 log units) below; measured number inside the range.
By their numbers in this assay, from the lowest: compounds 1, 2 and 3 (each within the scatter of the next); then compound 4.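

Going by these compounds alone, the exchange of 3-nitrophenyl for 6-methylpyridin-3-yl on the carbonyl carbon gives a 7.2-fold higher number from compound 1 to compound 4 (0.86 log units; beyond the scatter) in this assay, the only step so far that leaves the scatter, so the tolerance suggested by a 1.7-fold higher number from compound 1 to compound 2 (0.22 log units; within the scatter) does not extend to replacing the whole ring. That earlier step added a group to the 3-nitrophenyl ring and kept the ring itself, whereas this one changes the ring type, removes the nitro and brings in a methyl all at once, and the step cannot assign its size to any one of these changes. Nothing at hand explains the size of the step.

The compounds shown leave open which of these changes carries the step: an unsubstituted phenyl or an unsubstituted pyridine ring on the carbonyl carbon would begin to separate the loss of the nitro from the change of ring type. On these data alone, it also remains open whether a nitrile, an amine or a carboxylic acid in place of the nitro on the phenyl ring would keep the number close to that of compound 1.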